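Replacing methylcarbamoyl in compound 3: what clearance to expect

This account rests on a few compounds, and the source may have more. Where it says the series, first, only, none or still open, it means among the compounds named here.

Compound 1 `Nc1nccc(COc2ccc3nc(N[C@@H]4CCCC[C@H]4O)sc3c2)c1Cl` gives 25 mL/min/kg
Compound 2 `Nc1nccc(COc2cc(Cl)c3nc(N[C@@H]4CCCC[C@H]4O)sc3c2)c1Cl` gives 32 mL/min/kg
Compound 3 `CNC(=O)Nc1nccc(COc2cc(OC)c3nc(N[C@H]4CCCC[C@@H]4O)sc3c2)n1` gives 23 mL/min/kg

All three values come from an ADME assay on microsomes from liver (Homo sapiens) for pharmacokinetics, read by LC-MS, using NADPH, with a stated time of 45 min, tested at 1 uM (on this read-out lower numbers stand for slow clearance and higher numbers for fast clearance), and they sit close together. Compound 3 lies within the usual scatter of both compound 1 and compound 2, so the numbers do not separate it from either.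

Compound 4 `COc1cc(OCc2ccnc(Nc3cn(C)nn3)n2)cc2sc(N[C@H]3CCCC[C@@H]3O)nc12` differs from compound 3 on a nitrogen on an aromatic ring, where 1-methyl-1H-1,2,3-triazol-4-yl stands in place of methylcarbamoyl (1-methyl-1H-1,2,3-triazol-4-yl in place of methylcarbamoyl on a nitrogen on an aromatic ring). Within the data shown here, only one measured step is available for comparison (a 1.3-fold higher number from compound 1 to compound 2 (0.11 log units; within the scatter)). It puts chloro in place of hydrogen on an aromatic carbon, which is a different change in a different place, so it is weak guidance. No measurement covers the new group, so the data give no direction, and no shift beyond the scatter is expected in this assay while the uncertainty stays wide. The expected change is small (a 1.1-fold higher number from compound 3 to compound 4 (0.04 log units; within the scatter)). Compound 4 is therefore estimated at 25 mL/min/kg (expected range 12 mL/min/kg to 48 mL/min/kg).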

Compound 4, clearance: 43 mL/min/kg
Compound 4: middle estimate off by 1.7-fold (0.24 log units), on the low side; low and high end bracket the measured number.
By their numbers in this assay, from the lowest: compounds 3, 1, 2 and 4 (each within the scatter of the next).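

In this assay, putting 1-methyl-1H-1,2,3-triazol-4-yl in place of methylcarbamoyl on a nitrogen on an aromatic ring gives a 1.9-fold higher number from compound 3 to compound 4 (0.27 log units; within the scatter). Among these compounds, this is the first measured step at this place, and it shows that an open group with a hydrogen-bond donor can give way to a five-membered aromatic ring with no donor while the clearance numbers stay too close to tell apart. No measurement here offers an explanation for the size of this step.

This single pair leaves open whether a different result would come from a plain acetyl group, a simple methyl or a triazole without its methyl on this nitrogen. It also leaves open whether the same swap would give a similar step with chloro in place of the methoxy group on the shared core.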